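From thiophen-3-yl to 2,5-dimethylthiophen-3-yl

The source may report more compounds than this note shows. Statements on the series, on what has been measured and on what is new or still open speak of the compounds shown alone.

Of the compounds shown here, three have numbers so far in a functional assay on cells (Cancer cell lines, Homo sapiens) for inhibition; a higher number here means a weaker inhibitor of growth, a lower number a stronger inhibitor of growth. Compound 1 `Cc1cn2c(/C=N/Nc3ccccn3)c(-c3ccc(Cl)c([N+](=O)[O-])c3)nc2s1` gives 13800 nM, compound 2 `N=C(N)N/N=C/c1c(-c2cc(Cl)sc2Cl)nc2n1CCS2` gives 12300 nM, and compound 3 `N=C(N)N/N=C/c1c(-c2ccsc2)nc2n1CCS2` gives 32400 nM. Compound 3 thus has the highest number of the three, and its gaps to the other two both lie beyond the scatter.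

Compound 4 `Cc1cc(-c2nc3n(c2/C=N/NC(=N)N)CCS3)c(C)s1` has not yet been measured. It differs from compound 3 in a single group, with 2,5-dimethylthiophen-3-yl in place of thiophen-3-yl on an aromatic carbon.

Within the data shown here, one measured step bears on this change. It is a 2.6-fold higher number from compound 2 to compound 3 (0.42 log units; beyond the scatter), which comes with thiophen-3-yl in place of 2,5-dichlorothiophen-3-yl. That step is modest but beyond the scatter, and the compound with the bare thiophen-3-yl has the higher number. The group in compound 4 carries methyl where the group in compound 2 carries chloro. Among the measured compounds shown here, no measured compound has 2,5-dimethylthiophen-3-yl, so this single comparison is only a loose guide.

A modest fall in this assay is therefore expected, of about the same size as that single step, and the estimated change is a 2.0-fold lower number from compound 3 to compound 4 (0.31 log units; beyond the scatter). Compound 4 is estimated at 16000 nM, with an expected range from 7000 nM to 36000 nM.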

Compound 4, concentration for 50% growth inhibition: 24000 nM
For compound 4 the middle estimate is 1.5-fold (0.18 log units) below the measured one; low and high end bracket the measured number.
By their numbers in this assay, from the lowest: compounds 2, 1, 4 and 3 (each within the scatter of the next, the first and the last beyond it).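

In this assay, 2,5-dimethylthiophen-3-yl in place of thiophen-3-yl on this aromatic carbon gives a 1.4-fold lower number from compound 3 to compound 4 (0.13 log units; within the scatter) and so brings no change that can be told from the scatter. Set against the dichloro group, the same dimethyl group gives a 2.0-fold higher number from compound 2 to compound 4 (0.29 log units; within the scatter) and so cannot be separated from 2,5-dichlorothiophen-3-yl either, even though the earlier step of a 2.6-fold higher number from compound 2 to compound 3 (0.42 log units; beyond the scatter) does separate the dichloro and bare thiophene groups; compound 4 therefore resolves neither way, and the methyl groups do not clearly reproduce or clearly lose what the chloro groups gave. Nothing measured here offers an explanation for these numbers.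

The compounds shown leave open whether a single chloro or a single methyl on the thiophen-3-yl would give the same numbers as the pairs do, and whether other groups on that ring, such as trifluoromethyl or methoxy, would give a step beyond the scatter. They also leave open whether a phenyl in place of the thiophene would hold these numbers, and whether any of these changes would read the same on the core of compound 1.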